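Toxicity limit and the 4-bromophenyl change on compound 1

The source may report more compounds than this note shows. Statements on the series, on what has been measured and on what is new or still open speak of the compounds shown alone.

Compound 1 (`COc1ccc(-c2cnc(NC(=O)c3ncc[nH]3)n2C)cc1`) is the starting point in a toxicity assay on THP-1 cells (Homo sapiens) for inhibition; a higher number here means that more compound is tolerated, a lower number that less compound is tolerated. Compound 1 gives > 100000 nM, which is a limit and not a number. Compound 2 (`Cn1c(-c2ccccc2)cnc1NC(=O)c1ccc(F)cc1`), which has a six-membered aromatic ring of carbon only on its carbonyl carbon, gives > 100000 nM, also a limit. Compound 3 (`COc1ccc(-c2nc3ncc(-c4ccc(F)cc4)cc3[nH]2)cc1`) gives > 100000 nM, again a limit. Among the compounds with values here, the whole set stands at the limit of > 100000 nM in this assay, at which 3 of the 3 values shown sit, so the series offers no measured step.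

Compound 4 (`COc1ccc(-c2cnc(NC(=O)c3ccc(Br)cc3)n2C)cc1`) differs from the starting point by a single change, 4-bromophenyl in place of 1H-imidazol-2-yl on a carbonyl carbon. No step beyond the usual scatter is expected in this assay, and the expectation leans on compound 2 with its limit of > 100000 nM. The estimated step runs an at least 1.1-fold lower number from compound 1 to compound 4 (0.07 log units; that floor lies within the scatter). For compound 4 the expected value is 85000 nM, with an estimated range of 30000 nM to 150000 nM.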

Compound 4, half-maximal cytotoxic concentration: > 100000 nM
Compound 4 gave a limit, no number; the forecaster's own chance of this, stated with the estimate: 80%; middle value at least 1.1-fold (0.07 log units) from the limit.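

In this assay, within the data shown here, compound 4 gives > 100000 nM, a limit and not a number; compound 1 is also a limit, so no step between compound 1 and compound 4 can be read. The compounds shown leave open whether 4-bromophenyl in place of 1H-imidazol-2-yl on a carbonyl carbon changes tolerance at all.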